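Amine substituent variation on the diaryl ether core

The compounds below may be only part of what the source reports. "The series", "measured", "known", "first", "only" and "open" are said of these compounds alone.

Measured so far in a functional assay on SW-620 cells (Homo sapiens) for inhibition, read by MTT assay, with a stated time of 72 h; on this read-out lower numbers stand for stronger inhibition and higher numbers for weaker inhibition:
compound 1 `COc1cc(Oc2cccc(Nc3ccccc3)c2)cc(OC)c1CNCc1ccc(C)cc1` gives 11800 nM
compound 2 `CCN1CCN(Cc2c(OC)cc(Oc3cccc(Nc4ccccc4)c3)cc2OC)CC1` gives > 20000 nM, a limit of the assay
compound 3 `COc1cc(Oc2cccc(Nc3ccccc3)c2)cc(OC)c1CNC(C)C` gives > 20000 nM, a limit of the assay

Compound 3 stands at the limit of this assay and carries no number. Among the compounds with values here, two of the three values shown sit at that limit (the limit of > 20000 nM in this assay, at which 2 of the 3 values shown sit), so compound 1 is the only compound with a read number. Compound 4 `COc1cc(Oc2cccc(Nc3ccccc3)c2)cc(OC)c1CNCc1ccc(O)cc1` differs from compound 3 by 4-hydroxybenzyl in place of isopropyl on an amine nitrogen. Within the data shown here, the one measured step that bears on this change is an at least 1.6-fold higher number from compound 1 to compound 3 (0.22 log units; that floor lies within the scatter), the reverse exchange on the same amine nitrogen, read only as a floor that lies within the scatter. Restoring a benzyl group from isopropyl is therefore expected to bring the number back from the limit, at most modestly. The hydroxy in place of methyl on the benzyl ring has no measured counterpart among these compounds. Compound 4 is expected to give 14000 nM in this assay, within 5000 nM to 40000 nM. The expected step is an at least 1.4-fold lower number from compound 3 to compound 4 (0.15 log units; that floor lies within the scatter), with a fair chance that only a limit is reported.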

Compound 4, half-maximal inhibitory concentration: 7940 nM
Estimate against measurement, compound 4: 1.8-fold (0.25 log units) above; the range from low to high includes it.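

In this assay, within the data shown here, 4-hydroxybenzyl on the amine nitrogen gives the first readable steps beyond the scatter: an at least 2.5-fold lower number from compound 3 to compound 4 (0.40 log units; beyond the scatter) and an at least 2.5-fold lower number from compound 2 to compound 4 (0.40 log units; beyond the scatter). Both steps are floors and not full sizes, as compound 2 and compound 3 stand at a limit of the assay: the limit of > 20000 nM in this assay, at which 2 of the 4 values shown sit.
Hydroxy in place of methyl on an aromatic carbon gives a 1.5-fold lower number from compound 1 to compound 4 (0.17 log units; within the scatter), so compound 1 and compound 4 cannot be ordered, and the two groups are not told apart at this place.

The compounds shown leave open whether the unsubstituted benzyl group would read like these two or whether the hydroxy adds anything to it. Also open, on these data alone, is how a methoxy or a fluorine on the benzyl ring, or a longer chain such as phenethyl on the amine nitrogen, would read.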